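Cyclopropyl in Place of Pyridin-3-yl on a Ring Carbon

The source may hold more compounds than are shown below. What is called first, only, known or untested is meant among the compounds shown, and "the series" means these compounds.

Measured compounds:
compound 1, `COc1cccc(-c2ccc(COC3(C)CN(C#N)C3)cc2)c1`: 0.36 nM
compound 2, `COc1ccc(-c2ccc(COC3(c4cccnc4)CN(C#N)C3)c(F)c2)cc1F`: 2 nM

Of the compounds shown here, two have been measured in an assay for inhibition of Fatty-acid amide hydrolase 1 (Homo sapiens), read by fluorescence; on this read-out higher numbers stand for weaker inhibition and lower numbers for stronger inhibition. Compound 1 `COc1cccc(-c2ccc(COC3(C)CN(C#N)C3)cc2)c1` gives 0.36 nM, and compound 2 `COc1ccc(-c2ccc(COC3(c4cccnc4)CN(C#N)C3)c(F)c2)cc1F` gives 2 nM. Compound 2 therefore stands at the higher of the two numbers, the weaker inhibitor of the pair, and the gap to compound 1 lies beyond the scatter. For the measured compounds named here, the two compounds differ in several places at once, so no single structural step between them has been measured.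

Compound 3 `COc1ccc(-c2ccc(COC3(C4CC4)CN(C#N)C3)c(F)c2)cc1F` is the next compound. It keeps the shared core of compound 2 and differs from it in one place: cyclopropyl in place of pyridin-3-yl on a saturated ring carbon. Compound 1 carries a methyl group on the saturated ring carbon and gives the lower number, but it also differs from compound 2 elsewhere, so its value gives no direct measure of what the group on that carbon contributes. Going by the values given here, with no measured step to rest on, the change from compound 2 to compound 3 is expected to be small, a 1.3-fold lower number from compound 2 to compound 3 (0.12 log units; within the scatter), with no clear direction beyond the scatter. Compound 3 is expected to give 1.5 nM in this assay, within a range of 0.4 nM to 6 nM.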

Compound 3, half-maximal inhibitory concentration: 1 nM
Compound 3: the middle estimate sits 1.5-fold (0.18 log units) above what was measured, within the range that was stated.
By their numbers in this assay, from the lowest: compound 1; then compounds 3 and 2 (each within the scatter of the next).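

Cyclopropyl in place of pyridin-3-yl on a saturated ring carbon is the first change at this position that can be read on its own, and in this assay it gives a 2.0-fold lower number from compound 2 to compound 3 (0.30 log units; within the scatter). The position therefore accepts a three-membered non-aromatic ring of carbon only as well as a six-membered aromatic ring with 1 hetero atom: compound 2 and compound 3 do not separate, even though the hydrogen-bond acceptor of pyridin-3-yl leaves with that ring. Nothing available explains why the two groups read alike at this carbon.

Compound 1, which carries a methyl group on this carbon, gives 0.36 nM, but it differs from compound 3 in other places as well, so what the methyl group itself contributes stays unresolved. From the compounds shown here alone, whether an amine, a carboxylic acid or a longer alkyl chain on the same saturated ring carbon would also stay within the scatter of compound 3 remains open.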